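The source may hold more compounds than are shown below. What is called first, only, known or untested is meant among the compounds shown, and "the series" means these compounds.

Of the compounds shown here, two have been measured here, and a third waits for its number. Compound 1 `COc1ccccc1-c1n[nH]cc1N1CCCNCC1` and compound 2 `COc1ccc(-c2n[nH]cc2N2CCNCC2)cc1` share a core and differ in the ring attached to it and in where the methoxy group sits. In an assay on isolated protein for binding affinity to 5-hydroxytryptamine receptor 1D (Homo sapiens) (a lower number here means a stronger inhibitor, a higher number a weaker inhibitor), compound 1 gives > 10000 nM, a limit of the assay rather than a number. In this assay compound 2 likewise gives > 10000 nM, again a limit and not a measured number. So compound 2 stands where both measured values stand: at the limit of > 10000 nM in this assay, at which 2 of the 2 values shown sit, with nothing more exact known about it.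

Compound 3 `Cc1ccc(-c2n[nH]cc2N2CCNCC2)cc1` is the unmeasured compound. Compared with compound 2, the change is methyl in place of methoxy on an aromatic carbon. Within the data shown here, no step between two measured compounds is available, so the size of this change can only be expected, not read off. With both measured values sitting at a limit, the expected step from compound 2 to compound 3 is a step that the limit leaves unreadable from compound 2 to compound 3, none beyond the scatter. Compound 3 is therefore expected to give about 15000 nM, within a range from 5000 nM to 50000 nM, most likely again only a limit.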

Compound 3, inhibition constant: 325 nM
Estimate against measurement, compound 3: 46-fold (1.66 log units) above; the measured number lies below the stated range.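

Methyl in place of methoxy on an aromatic carbon, para to a large group, produces an at least 30-fold lower number from compound 2 to compound 3 (1.48 log units; beyond the scatter) in this assay, and this is the first step here that can be read at all. Compound 3 gives 325 nM, a true number rather than a limit, so the shared core can carry measurable binding to this receptor, and the group at this one place has a large bearing on whether that binding appears. The true size of the step stays unknown, as the value for compound 2 is only a limit, and the other limit in the set still gives no exact number to compare: the limit of > 10000 nM in this assay, at which 2 of the 3 values shown sit.

One swap cannot separate the loss of the oxygen from the loss of one heavy atom, since methoxy and methyl differ in both at once. From the compounds shown here alone, it also remains open how a chlorine atom, an ethyl group, an amine or a bare hydrogen would fare at this place, and whether methyl would have the same effect on the ring of compound 1, which differs from compound 3 in more than one place.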